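This account rests on a few compounds, and the source may have more. Where it says the series, first, only, none or still open, it means among the compounds named here.

Working notes on the sulfonyl series.

Compound 1 `CCN(CC)S(=O)(=O)c1ccc(S(=O)(=O)N2CCC[C@@H](C(=O)N(C)C(C)C)C2)cc1` sits in the middle of the three numbers gathered so far. In a functional assay on MIA PaCa-2 cells (Homo sapiens) for inhibition, read by MTT assay, with a stated time of 7 days (on this read-out lower numbers stand for stronger inhibition and higher numbers for weaker inhibition), compound 1 gives 6200 nM. The nearest figure belongs to compound 3 `CCOC(=O)C1CCCCN1S(=O)(=O)c1ccc(S(=O)(=O)N(CC)CC)cc1`, which in this assay gives 24600 nM, a higher number than compound 1 by a margin beyond the usual scatter. The furthest figure belongs to compound 2 `CCOC(=O)[C@@H]1CCCN(S(=O)(=O)c2ccc(S(=O)(=O)N(CC)CC)c(F)c2)C1`, which in this assay gives 900 nM, a lower number than compound 1, again beyond the scatter. For the measured compounds named here, no pair among compounds 1, 2 and 3 differs in only one place, so none of these gaps can be tied to a single structural change.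

Compound 4 `CCN(CC)S(=O)(=O)c1ccc(S(=O)(=O)N2CCC[C@@H](C(=O)NC3CN(C(=O)OC(C)(C)C)C3)C2)cc1` is the next compound to be run. It differs from compound 1 by (1-(tert-butoxycarbonyl)azetidin-3-yl)amino in place of isopropyl(methyl)amino on a carbonyl carbon. The shared core of compound 1 is kept. Going by the values given here, no measured pair shows what a change of this kind at the amide does, so the expectation rests on compound 1 alone.

Within this assay the step from compound 1 to compound 4 is expected to be small, a 1.3-fold higher number from compound 1 to compound 4 (0.11 log units; within the scatter), probably not beyond the scatter and, if anything, toward a higher number. For compound 4 in this assay the estimated value is 8000 nM, with a range from 2500 nM to 25000 nM.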

Compound 4, half-maximal inhibitory concentration: 200 nM
Estimate against measurement, compound 4: 40-fold (1.60 log units) above; the whole stated range lies above it.
By their numbers in this assay, from the lowest: compound 4; then compound 2; then compound 1; then compound 3.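

The substituent on the carbonyl carbon is not a silent place in this series: in this assay, (1-(tert-butoxycarbonyl)azetidin-3-yl)amino in place of isopropyl(methyl)amino gives a 31-fold lower number from compound 1 to compound 4 (1.49 log units; beyond the scatter), the first gap here that can be tied to a single structural change. The exchange replaces a group with no ring and no hydrogen-bond donor by a larger one that holds a four-membered non-aromatic ring, a hydrogen-bond donor and hydrogen-bond acceptors, so several features change together and this one step cannot separate them. No measurement is at hand that bears on what lies behind the size of this step.

From the compounds shown here alone, it remains open which part of the entering group the step follows; a free azetidin-3-yl amine or a cyclobutylamino group on the same carbonyl carbon would help to separate the contribution of the tert-butoxycarbonyl from that of the ring. Going by these compounds, it also remains open whether the gain carries over to a core bearing the fluorine of compound 2, as that compound differs from the others in more than one place.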